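The source may hold more compounds than are shown below. What is called first, only, known or untested is meant among the compounds shown, and "the series" means these compounds.

Compound 1 `O=C(Nc1ccc(Cl)c(-c2nnc3c(Cl)cccn23)c1)c1ccc(F)cc1Cl` carries 2-chloro-4-fluorophenyl on the carbonyl carbon of the amide. In a functional assay on U-251 cells (Homo sapiens) for antiproliferative activity, read by MTT assay, with a stated time of 72 h (on this read-out lower numbers stand for stronger inhibition and higher numbers for weaker inhibition), compound 1 gives > 100000 nM, which is a limit of the assay and not a number. Compound 2 `Cc1nc(C(=O)Nc2ccc(Cl)c(-c3nnc4c(Cl)cccn34)c2)cs1`, with 2-methyl-1,3-thiazol-4-yl on the carbonyl carbon, gives 74300 nM in this assay. Compound 3 `Cc1cc(Cl)ccc1C(=O)Nc1ccc(Cl)c(-c2nnc3c(Cl)cccn23)c1` carries 4-chloro-2-methylphenyl on the carbonyl carbon. In this assay compound 3 gives > 100000 nM, again a limit of the assay. The measured steps are an at least 1.3-fold lower number from compound 1 to compound 2 (0.12 log units; that floor lies within the scatter), a step that the two limits leave unreadable from compound 1 to compound 3 and an at least 1.3-fold higher number from compound 2 to compound 3 (0.12 log units; that floor lies within the scatter). Two of the three values sit at the limit of > 100000 nM in this assay, at which 2 of the 3 values shown sit, so compound 1 stands at the limit, with no number of its own.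

Compound 4 `CS(=O)(=O)c1ccc(C(=O)Nc2ccc(Cl)c(-c3nnc4c(Cl)cccn34)c2)c(Cl)c1` differs from compound 1 by methylsulfonyl in place of fluoro on an aromatic carbon. Going by the values given here, none of the measured steps touches this position; all three exchange the whole ring on the carbonyl carbon, the readable ones have floors that lie within the scatter, and one is unreadable between two limits. The step expected in this assay is therefore an at least 1.1-fold lower number from compound 1 to compound 4 (0.04 log units; that floor lies within the scatter), none beyond the scatter. For compound 4 the estimate is 90000 nM, with a range from 35000 nM to 250000 nM.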

Compound 4, half-maximal inhibitory concentration: 44600 nM
Estimate against measurement, compound 4: 2.0-fold (0.30 log units) above; the range from low to high includes it.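

Methylsulfonyl in place of fluoro, on the aromatic carbon meta to a chloro group and para to a large group, gives the only step shown that lies beyond the scatter in this assay, and it does so with the rest of the ring unchanged: an at least 2.2-fold lower number from compound 1 to compound 4 (0.35 log units; beyond the scatter). Compound 1 gives > 100000 nM, which is a limit of the assay and not a number. The step is therefore only a floor, because compound 1 has no number of its own: the limit of > 100000 nM in this assay, at which 2 of the 4 values shown sit.

Going by these compounds, whether an amine, a carboxylic acid or a nitrile at this position would match methylsulfonyl stays open. Also open, on these data alone, is whether methylsulfonyl would bring a readable value on the ring of compound 3.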